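Swapping fluoro for methoxy on the outer phenyl ring

The source may report more compounds than this note shows. Statements on the series, on what has been measured and on what is new or still open speak of the compounds shown alone.

Compound 1, `O=[N+]([O-])c1ccc(CN2CCC(n3cc(CC(OCc4cc(-c5ccc(Br)cc5)no4)c4ccc(Br)cc4)nn3)CC2)cc1`, gives in a functional assay on MDA-MB-231 cells (Homo sapiens) for cytotoxicity, with a stated time of 48 h (a lower number here means a stronger inhibitor, a higher number a weaker inhibitor), only a limit, > 25000 nM.
Compound 2, `N#Cc1ccc(-c2cc(COC(Cc3cn(C4CCN(Cc5ccc([N+](=O)[O-])cc5)CC4)nn3)c3ccc(Br)cc3)on2)cc1`, gives in this assay again only a limit, > 25000 nM.
Compound 3, `O=[N+]([O-])c1ccc(CN2CCC(n3cc(CC(OCc4cc(-c5cccc(F)c5)no4)c4ccc(Br)cc4)nn3)CC2)cc1`, gives in this assay 5000 nM.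

Among the measured compounds shown here, compound 3 thus holds the only number among the three values; the other two sit at the limit of > 25000 nM in this assay, at which 2 of the 3 values shown sit. Compound 4, `COc1cccc(-c2cc(COC(Cc3cn(C4CCN(Cc5ccc([N+](=O)[O-])cc5)CC4)nn3)c3ccc(Br)cc3)on2)c1`, differs from compound 3 by methoxy in place of fluoro on an aromatic carbon. For the measured compounds named here, two measured steps touch the same outer phenyl ring: an at least 5.0-fold lower number from compound 1 to compound 3 (0.69 log units; beyond the scatter) and an at least 5.0-fold lower number from compound 2 to compound 3 (0.69 log units; beyond the scatter), each exchanging a 4-bromophenyl or 4-cyanophenyl for a 3-fluorophenyl. The step that the two limits leave unreadable from compound 1 to compound 2 cannot be sized. These steps show that a change on this ring can move the number by a modest amount, but none of them tests a methoxy, and none keeps the substituent at the same place while changing its kind. A small step is therefore expected, probably toward a weaker compound, with a real chance of returning to the limit. Compound 4 is estimated at 8000 nM, between 2500 nM and 25000 nM, which would mean an expected 1.6-fold higher number from compound 3 to compound 4 (0.20 log units; within the scatter).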

Compound 4, half-maximal inhibitory concentration: > 25000 nM
Compound 4 gave a limit, no number (the forecaster's own chance of this, stated with the estimate: 30%); middle value at least 3.1-fold (0.49 log units) away from the limit.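

With the substituent kept at the same place on the outer phenyl ring, the exchange of fluoro for methoxy gives an at least 5.0-fold higher number from compound 3 to compound 4 (0.69 log units; beyond the scatter) in this assay and is a clear loss of activity. The earlier steps shown here changed the kind of substituent and its place together, whereas this one changes only the kind, so it shows that the kind of group at this place matters on its own. Compound 4 has only a limit and no number, and it joins compound 1 and compound 2 there, so the steps among these three cannot be read: the limit of > 25000 nM in this assay, at which 3 of the 4 values shown sit.

Going by these compounds, how far compound 4 lies past its limit remains unknown. Also open, on these data alone, is whether a chloro or an amino group at this place, or a plain phenyl with nothing there, would keep a measurable number as compound 3 does.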